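Replacing the 3,4,5-trimethoxyphenyl group of compound 2

This account rests on a few compounds, and the source may have more. Where it says the series, first, only, none or still open, it means among the compounds named here.

Measured in a functional assay on MCF7 cells (Homo sapiens) for cytotoxicity, read by MTT assay, with a stated time of 72 h; on this read-out lower numbers stand for stronger inhibition and higher numbers for weaker inhibition:
compound 1 `COc1cc2ncnc(Nc3ccc(F)c(Cl)c3)c2cc1NC(=O)N/N=C/c1ccc(F)cc1`: 35100 nM
compound 2 `COc1cc2ncnc(Nc3ccc(F)c(Cl)c3)c2cc1NC(=O)N/N=C/c1cc(OC)c(OC)c(OC)c1`: 30700 nM

Among the compounds with values here, compound 2 gives 30700 nM, level with compound 1 at 35100 nM, the only other compound measured so far. Compound 3 `COc1cc2ncnc(Nc3ccc(F)c(Cl)c3)c2cc1NC(=O)N/N=C/c1cc(Br)c(O)c(Br)c1` carries 3,5-dibromo-4-hydroxyphenyl in place of 3,4,5-trimethoxyphenyl on a carbon with a double bond to nitrogen. Within the data shown here, the one measured step at this place is a 1.1-fold lower number from compound 1 to compound 2 (0.06 log units; within the scatter), which exchanged 4-fluorophenyl for 3,4,5-trimethoxyphenyl and stayed within the scatter. Among the measured compounds shown here, no measured compound carries bromine or a hydroxy group here, so the expectation rests on that single step. In this assay, no step beyond the scatter is expected, and the estimated step is a 1.3-fold lower number from compound 2 to compound 3 (0.11 log units; within the scatter). Compound 3 is expected at 24000 nM, with an estimated range from 8000 nM to 60000 nM.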

Compound 3, half-maximal inhibitory concentration: 30200 nM
Beside the measured number, compound 3's estimate is 1.3-fold (0.10 log units) below it; the range from low to high includes it.
By their numbers in this assay, from the lowest: compounds 3, 2 and 1 (each within the scatter of the next).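

In this assay, 3,5-dibromo-4-hydroxyphenyl in place of 3,4,5-trimethoxyphenyl gives a 1.0-fold lower number from compound 2 to compound 3 (0.01 log units; within the scatter) and the same group in place of 4-fluorophenyl gives a 1.2-fold lower number from compound 1 to compound 3 (0.07 log units; within the scatter). All three groups on the carbon with a double bond to nitrogen therefore lie within the scatter of one another, and this now holds for a group bearing bromine and a hydroxy group, which neither earlier compound carried here. Nothing available explains why these exchanges leave the number level.

As far as these compounds go, all three compounds still carry a substituted phenyl ring at this place, so it remains open whether a carboxylic acid, an amine or a longer alkyl chain on the phenyl ring would move the number. The shared core also stays the same throughout, so the compounds shown say nothing about changes there.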